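Swapping the hydroxyphenyl of compound 1 for chlorophenyl

This account rests on a few compounds, and the source may have more. Where it says the series, first, only, none or still open, it means among the compounds named here.

Measured compounds:
- compound 1, `O=C(Nc1ccccc1O)c1cccc(N2C(=O)c3ccccc3C2=O)c1`, 77 nM
- compound 2, `COc1ccccc1C(=O)Nc1cccc(NC(=O)c2cccc(F)c2)c1`, 6480 nM
- compound 3, `O=C(Nc1cccc(NC(=O)C2CCC2)c1)c1cccc(Cl)c1`, 5270 nM

In an in vitro functional assay on HEK293-A cells for antagonist activity at metabotropic glutamate receptor 5 (Rattus norvegicus), read by calcium flux (a lower number here means a stronger inhibitor, a higher number a weaker inhibitor), compound 1 stands lowest of the three numbers, and both of its neighbours lie beyond the usual scatter: compound 3 gives 5270 nM and compound 2 gives 6480 nM, so compound 1 is the strongest inhibitor among the three by a clear margin. Going by the values given here, neither compound 2 nor compound 3 shares the core of compound 1 in a single-point way, so no step between measured compounds is available to read from.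

Compound 4, `O=C(Nc1cccc(Cl)c1)c1cccc(N2C(=O)c3ccccc3C2=O)c1`, is not yet measured. It differs from compound 1 in one place: 3-chlorophenyl in place of 2-hydroxyphenyl on an amide-type nitrogen. The change removes the one hydrogen-bond donor and the one hydrogen-bond acceptor that the leaving group carried. Among the compounds with values here, with no measured step to guide it, the expectation for the step in this assay from compound 1 to compound 4 is a moderate loss of inhibition, beyond the scatter but well short of the gaps seen to compound 2 and compound 3, and it is estimated as a 5.2-fold higher number from compound 1 to compound 4 (0.72 log units; beyond the scatter). Compound 4 is therefore expected to give about 400 nM, within a range of 80 nM to 2000 nM.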

Compound 4, half-maximal inhibitory concentration: 1780 nM
For compound 4 the middle estimate is 4.5-fold (0.65 log units) below the measured one, within the range that was stated.
By their numbers in this assay, from the lowest: compound 1; then compound 4; then compounds 3 and 2 (each within the scatter of the next).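

In this assay, going by these compounds alone, the swap gives a 23-fold higher number from compound 1 to compound 4 (1.36 log units; beyond the scatter), the first single-place step, and it shows that the group on this amide-type nitrogen strongly affects inhibition with the rest of compound 1 held constant. The size of the step is notable given how much the two groups have in common: 2-hydroxyphenyl and 3-chlorophenyl have the same heavy-atom count, the same six-membered aromatic carbon ring and no net charge, whereas the leaving group has a hydrogen-bond donor and a hydrogen-bond acceptor and the entering group has neither. No measurement shown here accounts for the loss of inhibition.

This single step changes both the identity of the ring substituent and its place on the ring, so the compounds shown cannot separate the two contributions or assign the loss to the missing hydroxyl. From the compounds shown here alone, it also remains open how an amine or a methoxy group on that ring would compare with the hydroxyl of compound 1, and whether the same change would have a similar effect on a different core.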